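The compounds below may be only part of what the source reports. "The series", "measured", "known", "first", "only" and "open" are said of these compounds alone.

Going by the values given here, compound 1, with the structure `CNC(=O)/C=C/c1ccncc1-c1ccc2c(cnn2C)c1`, is the only compound in this set with a measured number. In a functional assay on HCT-116 cells (Homo sapiens) for inhibition, read by MTT assay, with a stated time of 72 h (on this read-out lower numbers stand for stronger inhibition of growth and higher numbers for weaker inhibition of growth), compound 1 gives 3480 nM, which places it as the sole reference point here. A second compound, compound 2 with the structure `COC1CN(C(=O)/C=C/c2ccncc2-c2ccc(F)cc2)C1`, belongs to the same study, but in this assay compound 2 gives "not determined" (no result reported), so it offers no comparison. Compound 3, with the structure `Cn1ncc2cc(-c3cnccc3/C=C/C(=O)O)ccc21`, has not yet been measured. It differs from compound 1 in one place: hydroxy in place of methylamino on a carbonyl carbon. Among the compounds with values here, no pair of measured compounds in this set shows such a change, so the size of the step cannot be read off directly. Because compound 1 stands at 3480 nM, and exchanging a methylcarbamoyl group for a carboxy group is a noticeable alteration of the chain end, the step of a 4.3-fold higher number from compound 1 to compound 3 (0.63 log units; beyond the scatter) is expected to go beyond the usual scatter, toward weaker inhibition of growth. On this basis compound 3 is estimated at 15000 nM, with a plausible range from 4000 nM to 60000 nM, pending the actual measurement.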

Compound 3, concentration for 50% growth inhibition: > 30000 nM
Compound 3 gave a limit, no number; the forecaster's own chance of this, stated with the estimate: 30%; middle value at least 2.0-fold (0.30 log units) away from the limit.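

Until now, compound 1 stood alone with a number, so nothing showed whether growth inhibition responds to a change at the chain end. In this assay, putting hydroxy in place of methylamino on the carbonyl carbon gives an at least 8.6-fold higher number from compound 1 to compound 3 (0.93 log units; beyond the scatter), which shows that this position is sensitive to the change and that the direction is toward weaker inhibition of growth. Compound 3 is reported as a limit and not as a number, so the step has a lower bound but no upper bound: the limit of > 30000 nM in this assay, at which 1 of the 3 values shown sits.

The compounds shown compare only two groups on this carbonyl carbon, so they leave open how far the true value of compound 3 lies past the limit and whether the amide nitrogen or its methyl matters more. A simple primary amide, an ethylamino group or a methoxy group at the same place would help separate these possibilities, since each keeps or alters a different part of the methylcarbamoyl group of compound 1.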